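Side-chain variation at the amino ester position: compound 4

The compounds below may be only part of what the source reports. "The series", "measured", "known", "first", "only" and "open" are said of these compounds alone.

Compound 3 `CSCC[C@H](NC(=O)CN(c1ncnc2c1ncn2C1CCCCO1)C1CC1)C(=O)OCc1ccccc1` gives 28.7% in a functional assay on the whole organism (Tail, strain ICR) with Mus musculus as the target, in the tail flick test, with a stated time of 120 min, at a dose of 25 umol/kg by the oral route; a lower number here means a weaker effect, a higher number a stronger effect of the compound at the dose given. Compound 1 `NC(=O)CC[C@H](NC(=O)CN(c1ncnc2c1ncn2C1CCCCO1)C1CC1)C(=O)OCc1ccccc1` gives 22.3%, and compound 2 `CC[C@H](C)[C@H](NC(=O)CN(c1ncnc2c1ncn2C1CCCCO1)C1CC1)C(=O)OCc1ccccc1` gives 20.4%; since a number 6.4 percentage points higher from compound 1 to compound 3 (within the scatter) and a number 8.3 percentage points higher from compound 2 to compound 3 (within the scatter) both lie within the scatter, the three numbers cannot be told apart, and compound 3 is merely the one with the largest figure. Compound 4 `O=C(CN(c1ncnc2c1ncn2C1CCCCO1)C1CC1)N[C@@H](CCC(=O)OCc1ccccc1)C(=O)OCc1ccccc1` differs from compound 3 as follows: benzyloxycarbonyl in place of methylsulfanyl on a saturated chain carbon, three bonds along the chain from an amide-type nitrogen and a carbonyl carbon. The step that bears on this change at the same place is a number 6.4 percentage points higher from compound 1 to compound 3 (within the scatter), within the scatter; a number 8.3 percentage points higher from compound 2 to compound 3 (within the scatter) and a number 1.9 percentage points lower from compound 1 to compound 2 (within the scatter) are likewise within it. No step beyond the scatter is therefore expected, estimated as a number 3.7 percentage points lower from compound 3 to compound 4 (within the scatter). For compound 4 the expected value is 25%, with a range from 12% to 38%.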

Compound 4, a percentage reported as activity, at one dose (the size of the read-out at that dose, not a potency): 20.7%
For compound 4 the middle estimate is 4.3 percentage points above the measured one; measured number inside the range.
By their numbers in this assay, from the lowest: compounds 2, 4, 1 and 3 (each within the scatter of the next).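

In this assay, this side chain takes benzyloxycarbonyl with its aromatic ring and shows no step beyond the scatter against methylsulfanyl (a number 8 percentage points lower from compound 3 to compound 4 (within the scatter)) or sec-butyl as the group on the chain carbon (a number 0.3 percentage points higher from compound 2 to compound 4 (within the scatter)). Benzyloxy in place of amino on the carbonyl carbon is equally unresolved (a number 1.6 percentage points lower from compound 1 to compound 4 (within the scatter)). No evidence accounts for this.

Going by these compounds, whether a free carboxylic acid or a primary amine at the end of this chain would give a step beyond the scatter stays open. So does the effect of a longer chain.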